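This account rests on a few compounds, and the source may have more. Where it says the series, first, only, none or still open, it means among the compounds named here.

Measured in a functional assay on CCRF-CEM cells (Homo sapiens) for antiproliferative activity; on this read-out lower numbers stand for stronger inhibition and higher numbers for weaker inhibition:
- Compound 1 `Nc1nc(=O)n([C@H]2C=C[C@@H](CO)O2)cc1I`: 107000 nM
- Compound 2 `O=c1[nH]c(=O)n([C@@H]2C=C[C@@H](CO)O2)cc1F`: 11400 nM

Compound 2 holds the lower of the two numbers, and its gap to compound 1 lies beyond the usual scatter. Compound 3 `O=c1[nH]c(=O)n([C@@H]2C=C[C@H](CO)O2)cc1F` has the same atoms and bonds as compound 2 and differs only in configuration as drawn (the two compounds have the same atoms and bonds and differ only in configuration as drawn: 1 of 2 stereo elements differ; a stereocentre at a saturated ring carbon is drawn S in compound 2 and R in compound 3): a stereocentre at a saturated ring carbon is drawn S in compound 2 and R in compound 3. Within the data shown here, no measured pair here shows what such an inversion does, so the expectation rests on judgment alone. A modest step towards weaker inhibition in this assay is expected. The expected change is a 2.6-fold higher number from compound 2 to compound 3 (0.42 log units; beyond the scatter). The estimated value for compound 3 is 30000 nM, with an expected range from 5000 nM to 120000 nM.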

Compound 3, half-maximal inhibitory concentration: 12900 nM
Beside the measured number, compound 3's estimate is 2.3-fold (0.37 log units) above it; the range from low to high includes it.
By their numbers in this assay, from the lowest: compounds 2 and 3 (each within the scatter of the next); then compound 1.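

The inversion of the stereocentre at a saturated ring carbon, from S to R, comes with a 1.1-fold higher number from compound 2 to compound 3 (0.05 log units; within the scatter) in this assay. Among these compounds, compound 1 could not show this, since it stands apart from the other compounds in more than one place; here, for the first time, a single change can be read, and on this read-out the configuration at this stereocentre does not separate the two numbers. The comparison isolates that one stereo element: the fact that compounds 2 and 3 differ only in the configuration as drawn

On these data alone, whether the second stereo element would behave the same way when inverted on its own remains open. As far as these compounds go, it is also open whether the same indifference to configuration would hold with a different group at this stereocentre, such as an aminomethyl group or a carboxylic acid.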